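Aryl swap on the saturated ring carbon: compound 4

A few compounds are considered here, and "the series" means these few. Any claim that something is new, unique, unknown or untested is made for them only; others in the source may bear on it.

Compound 3 `N#CC1=C(N)N(c2ccc(S(N)(=O)=O)cc2)C2=C(CCCC2)C1c1ccc(Cl)cc1Cl` sits lowest of the three measured numbers in a functional assay on Ehrlich cells (Mus musculus) for cytotoxicity, read by trypan blue exclusion, with a stated time of 2 h, tested at 25 ug/mL; a higher number here means a stronger effect of the compound at the concentration tested, a lower number a weaker effect. In this assay compound 3 gives 50%. Compound 1 `N#CC1=C(N)N(c2ccc(S(N)(=O)=O)cc2)C2=C(CCCC2)C1/C=C/c1ccccc1` gives 70% in this assay, and compound 2 `COc1ccc(C2C(C#N)=C(N)N(c3ccc(S(N)(=O)=O)cc3)C3=C2CCCC3)cc1` gives 90%. The steps down to compound 3 are a number 20 percentage points lower from compound 1 to compound 3 (beyond the scatter) and a number 40 percentage points lower from compound 2 to compound 3 (beyond the scatter), the second being the largest gap in the set, while a number 20 percentage points higher from compound 1 to compound 2 (beyond the scatter). Compound 4 `N#CC1=C(N)N(c2ccc(S(N)(=O)=O)cc2)C2=C(CCCC2)C1c1ccc(Cl)c(Cl)c1` differs from compound 3 only in the aryl group on the saturated ring carbon: 3,4-dichlorophenyl in place of 2,4-dichlorophenyl on a saturated ring carbon. Among the compounds with values here, no measured step compares two dichlorophenyl isomers. The steps in hand exchange chemically different groups, so they bear on this change only loosely and give no direction for it. The expected step is a number 5 percentage points higher from compound 3 to compound 4 (within the scatter), which lies within the scatter. Compound 4 is therefore estimated at 55%, with a range from 35% to 80%.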

Compound 4, a percentage reported as activity, at one concentration (the size of the read-out at that concentration, not a potency): 40%
Estimate against measurement, compound 4: 15 percentage points above; low and high end bracket the measured number.
By their numbers in this assay, from the lowest: compounds 4 and 3 (each within the scatter of the next); then compound 1; then compound 2.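

In this assay, the step between the two dichlorophenyl isomers is a number 10 percentage points lower from compound 3 to compound 4 (within the scatter), so at this saturated ring carbon, the change from 2,4-dichlorophenyl to 3,4-dichlorophenyl, with the same atoms joined differently, does not separate the two compounds. The other new steps are a number 50 percentage points lower from compound 2 to compound 4 (beyond the scatter) and a number 30 percentage points lower from compound 1 to compound 4 (beyond the scatter), which place both dichlorophenyl compounds below the 2-phenylethenyl compound and the 4-methoxyphenyl compound, with no listed compound going against this grouping. Nothing available explains either the closeness of the isomers or their gap to the other two compounds.

Still open, from the compounds shown here alone, is whether that gap follows the chlorine atoms, the methoxy group or the aryl ring as a whole. An unsubstituted phenyl, a 4-chlorophenyl or a 4-hydroxyphenyl at this carbon would help separate these readings, and values at a single concentration give no potency for any of them.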